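The source may report more compounds than this note shows. Statements on the series, on what has been measured and on what is new or still open speak of the compounds shown alone.

Two compounds share a core built around a quinone-like ring carrying two aziridine groups, and they differ only in the side chain on one saturated chain carbon. Compound 1 `CC1=C(N2CC2)C(=O)C(CC(C)OC(N)=O)=C(N2CC2)C1=O` carries a carbamate-bearing chain there, and in a functional assay on L1210 cells (Mus musculus), with a stated time of 12 days (on this read-out higher numbers stand for higher potency (the scale is a negative logarithm) and lower numbers for lower potency), compound 1 gives 6.14. Compound 2 `CC1=C(N2CC2)C(=O)C(Cc2ccccc2)=C(N2CC2)C1=O` carries a phenyl group at the same place, and in this assay compound 2 gives 4.85, the lower of the two numbers; the step of a number 1.29 log units lower from compound 1 to compound 2 (beyond the scatter) is large and well beyond the scatter.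

Compound 3 `CC1=C(N2CC2)C(=O)C(CCCc2ccccc2)=C(N2CC2)C1=O` is the next compound, and its change from compound 2 is phenethyl in place of phenyl on a saturated chain carbon bound to a double-bonded ring carbon. Among the compounds with values here, no measured step bears directly on lengthening this chain: the only step known swaps one whole group for another of different composition. With nothing to guide the direction, compound 3 is expected to stay near compound 2, with an estimated step of a number 0.25 log units higher from compound 2 to compound 3 (within the scatter). For compound 3 in this assay the estimate is 5.1, within a range from 4.4 to 5.8.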

Compound 3, logarithm of the reciprocal of the active concentration, log(1/C): 4.47
Compound 3: the middle estimate sits 0.63 log units above what was measured, and the stated range covers the measured number.
By their numbers in this assay, from the lowest: compound 3; then compound 2; then compound 1.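

In this assay, the step of a number 0.38 log units lower from compound 2 to compound 3 (beyond the scatter) shows that at this position the longer phenethyl does not bring back the potency lost with phenyl, since the value falls further, though only modestly. The gap to the carbamate-bearing chain therefore widens, with a step of a number 1.67 log units lower from compound 1 to compound 3 (beyond the scatter), and both chains ending in a phenyl ring stand well short of that chain in these three compounds. No supporting measurement is available to explain this fall.

The compounds shown leave open whether a still longer chain ending in phenyl would continue the decline, or whether the trend would stop or reverse. They also leave open which part of the carbamate-bearing chain matters, something a hydroxyl or an amine on the same chain could help to separate.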